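This account rests on a few compounds, and the source may have more. Where it says the series, first, only, none or still open, it means among the compounds named here.

Compound 1 `O=S(=O)(c1ccccc1)c1ccc(O)nn1`: 95% in a functional assay on the whole organism for inhibition, with Rattus norvegicus as the target, at a dose of 50 mg/kg; a lower number here means a weaker effect, a higher number a stronger effect of the compound at the dose given
Compound 2 `O=S(=O)(c1ccc(Br)cc1)c1ccc(O)nn1`: 26% in this assay

Compound 2 gives the lower of these two numbers. Compound 3 `O=S(=O)(c1ccc(F)cc1)c1ccc(O)nn1` differs from compound 2 by fluoro in place of bromo on an aromatic carbon. Within the data shown here, the only measured step, a number 69 percentage points lower from compound 1 to compound 2 (beyond the scatter), is the one that bears on this change, but it exchanges hydrogen for bromo, not one halogen for another, so it is a partial guide. Because a number 69 percentage points lower from compound 1 to compound 2 (beyond the scatter) was large, a rise is expected for compound 3, a number 34 percentage points higher from compound 2 to compound 3 (beyond the scatter), though its size is uncertain. Compound 3 is therefore estimated at 60%, with a range from 30% to 90%.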

Compound 3, a percentage reported as inhibition, in the whole organism at one dose (the size of the read-out at that dose, not a potency): 81%
The estimate for compound 3 lay 21 percentage points below the measured number; the range from low to high includes it.
By their numbers in this assay, from the lowest: compound 2; then compound 3; then compound 1.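

At this place on the aromatic ring, the choice of halogen matters: in this assay, fluoro in place of bromo gives a number 55 percentage points higher from compound 2 to compound 3 (beyond the scatter), so the large loss seen with bromo does not carry over in full to fluoro. Fluoro in place of hydrogen gives only a number 14 percentage points lower from compound 1 to compound 3 (beyond the scatter), so neither halogen here matches the unsubstituted compound 1. Nothing available explains the gap between fluoro and bromo. The compounds shown leave open what a chloro group, a methoxy group or an amine would do at this same place.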